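The compounds below may be only part of what the source reports. "The series", "measured", "known", "first", "only" and "open" are said of these compounds alone.

Compound 2 `CC(C)CCn1c(CN2CCN(C(=O)C3CC3)CC2)nc2ccccc21` is one of three compounds tested in an assay on isolated protein for inhibition of aldehyde dehydrogenase 1A1 (Homo sapiens), read by spectrophotometry, tested at 10 uM; on this read-out lower numbers stand for less inhibition and higher numbers for more inhibition at the one concentration tested (going by the name of the read-out). In this assay compound 2 gives 70%, which sits close to the reading of compound 3 `CC(=O)N1CCN(Cc2nc3ccccc3n2Cc2cccc(C)c2)CC1`, where compound 3 gives 70.3%, and far above compound 1 `Cc1cccc(Cn2c(CN3CCN(C(=O)C4CCCCC4)CC3)nc3ccccc32)c1`, where compound 1 gives 31.9%. Compound 4 `O=C(C1CC1)N1CCN(Cc2nc3ccccc3n2CC2CC2)CC1` differs from compound 2 in one place: cyclopropyl in place of isobutyl on a saturated chain carbon bound to an aromatic nitrogen. Within the data shown here, the only measured step, a number 38.4 percentage points higher from compound 1 to compound 3 (beyond the scatter), concerns a group on a carbonyl carbon, a different place, so it gives no direct guide here. With nothing to point either way, the expected change is a number 5 percentage points lower from compound 2 to compound 4 (within the scatter), within the scatter. The estimate for compound 4 in this assay is therefore 65%, with a range from 45% to 85%.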

Compound 4, a percentage reported as inhibition, at one concentration (the size of the read-out at that concentration, not a potency): 21.2%
Compound 4: the middle estimate sits 43.8 percentage points above what was measured; the measured number lies below the stated range.
By their numbers in this assay, from the lowest: compound 4; then compound 1; then compounds 2 and 3 (each within the scatter of the next).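

In this assay, among these compounds, cyclopropyl in place of isobutyl on a saturated chain carbon bound to an aromatic nitrogen gives a number 48.8 percentage points lower from compound 2 to compound 4 (beyond the scatter), so this position, which no earlier step touched, has a large effect on the reading. The change replaces a group with no ring by one with a three-membered ring and fewer heavy atoms, and this single pair cannot separate those two differences. No measurement at hand explains the drop. As far as these compounds go, whether a cyclobutyl group or a straight butyl chain at this position would keep the higher reading remains open.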